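Adding one methoxy group to compound 3

A few compounds are considered here, and "the series" means these few. Any claim that something is new, unique, unknown or untested is made for them only; others in the source may bear on it.

Compound 1 `COc1ccc(/C=C2\CCC/C(=C\c3cccc(Br)c3)C2=O)cc1OC`: 5200 nM
Compound 2 `COc1ccccc1/C=C1\CCC/C(=C\c2ccc(OC)c(OC)c2)C1=O`: 8100 nM
Compound 3 `COc1ccc(/C=C2\CCC/C(=C\c3ccc(OC)c(OC)c3)C2=O)cc1`: 7200 nM

All three values come from a functional assay on HT-1080 cells (Homo sapiens) for cytotoxicity, read by MTT assay, with a stated time of 72 h; on this read-out lower numbers stand for stronger inhibition and higher numbers for weaker inhibition. Compound 3 cannot be separated from the other two on these numbers: the data show a 1.1-fold lower number from compound 2 to compound 3 (0.05 log units; within the scatter) and a 1.4-fold higher number from compound 1 to compound 3 (0.14 log units; within the scatter). The remaining pair behaves the same way, with a 1.6-fold higher number from compound 1 to compound 2 (0.19 log units; within the scatter).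

Compound 4 `COc1ccc(/C=C2\CCC/C(=C\c3ccc(OC)c(OC)c3)C2=O)c(OC)c1` differs from compound 3 in a single place: methoxy in place of hydrogen on an aromatic carbon. The methoxy takes the place of a hydrogen on an aromatic carbon, ortho to a large group and meta to a methoxy group.

For the measured compounds named here, no measured step adds a group in this way. The nearest evidence is the three steps above, which exchange one substituted phenyl group for another and leave this assay within the scatter each time. On that limited basis, no shift beyond the scatter is expected in either direction, and the estimated step is a 1.0-fold lower number from compound 3 to compound 4 (0.01 log units; within the scatter).

Compound 4 is therefore expected at 7000 nM, with an estimated range from 3500 nM to 13000 nM.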

Compound 4, half-maximal inhibitory concentration: 17100 nM
Beside the measured number, compound 4's estimate is 2.4-fold (0.39 log units) below it, outside the stated range (above it).
By their numbers in this assay, from the lowest: compounds 1, 3 and 2 (each within the scatter of the next); then compound 4.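

In this assay, for the compounds shown here, this is the first change to move the number beyond the scatter, with a 2.4-fold higher number from compound 3 to compound 4 (0.38 log units; beyond the scatter). Going by these compounds alone, the exchanges of one substituted phenyl group for another among compounds 1, 2 and 3 had all stayed within it, so the earlier compounds gave no sign that this ring could shift the result. The same methoxy in place of hydrogen on an aromatic carbon also gives a 2.1-fold higher number from compound 2 to compound 4 (0.32 log units; beyond the scatter), so compound 4, with both of the methoxy groups that compound 2 and compound 3 each carry singly on this ring, stands apart from both, and in the weaker direction.

Nothing given here accounts for this rise. The compounds shown leave open whether a hydroxy group, an amine or a longer chain such as ethoxy on this aromatic carbon would move the number the same way.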